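A few compounds are considered here, and "the series" means these few. Any claim that something is new, unique, unknown or untested is made for them only; others in the source may bear on it.

Compound 1 `COc1ccc2nc(NC(=O)CCCCC(=O)NO)sc2c1` gives 9.07 ug/mL
Compound 2 `CS(=O)(=O)c1ccc2nc(NC(=O)CCCCC(=O)NO)sc2c1` gives > 30 ug/mL which is a limit of the assay

Going by the values given here, in a functional assay on SW-620 cells (Homo sapiens) for cytotoxicity (a higher number here means a weaker inhibitor, a lower number a stronger inhibitor), compound 1 gives 9.07 ug/mL and is the only compound with an exact number so far. Compound 3 `O=C(CCCCC(=O)Nc1nc2ccccc2s1)NO` keeps the core of compound 1 but carries hydrogen in place of methoxy on an aromatic carbon and nothing else differs. One measured step also replaces the methoxy group: an at least 3.3-fold higher number from compound 1 to compound 2 (0.51 log units; beyond the scatter) with methylsulfonyl in place of methoxy. That step shows that replacing this group can shift the result, but it gives no direction for hydrogen. No clear change is therefore expected. For compound 3 the expected change in this assay is a 1.1-fold lower number from compound 1 to compound 3 (0.05 log units; within the scatter) and so stays within the scatter. For compound 3 the estimate is 8 ug/mL with an expected range from 3 ug/mL to 22 ug/mL around it.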

Compound 3, half-maximal inhibitory concentration: 7.85 ug/mL
Compound 3: the middle estimate sits 1.0-fold (0.01 log units) above what was measured; low and high end bracket the measured number.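

In this assay, swapping methoxy for hydrogen on this aromatic carbon makes no clear difference: the step is a 1.2-fold lower number from compound 1 to compound 3 (0.06 log units; within the scatter). The methoxy group is therefore not needed for the level seen with compound 1, and methylsulfonyl is the group that stands apart, as the hydrogen compound gives an at least 3.8-fold lower number from compound 2 to compound 3 (0.58 log units; beyond the scatter). The value of compound 2 is a limit of the assay and not an exact number: the limit of > 30 ug/mL in this assay, at which 1 of the 3 values shown sits.

With only methoxy, hydrogen and methylsulfonyl shown at this carbon, it remains open whether an amine or a carboxylic acid there would keep the number or shift it. On these data alone, it also remains open whether a longer chain on the shared core would change the result, and why methylsulfonyl differs from the other two groups.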